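Dropping One Methoxy Group from Compound 1

A few compounds are considered here, and "the series" means these few. Any claim that something is new, unique, unknown or untested is made for them only; others in the source may bear on it.

Compound 1 `COc1ccc(CNc2nc3cc(N)cc(N)c3nc2-c2ccccc2)cc1OC`: 81300 nM
Compound 2 `CCOC(=O)[C@H](CCC(=O)O)NC(=O)c1ccc(Sc2nc3cc(N)cc(N)c3nc2-c2ccccc2)cc1`: < 100000 nM
Compound 3 `COc1cc(CNc2nc3cc(N)cc(N)c3nc2-c2ccccc2)cc(OC)c1OC`: < 50200 nM

Among the compounds with values here, in a functional assay on OVCAR-5 cells (Homo sapiens) for inhibition, read by sulforhodamine B assay, with a stated time of 48 h (a higher number here means that more compound is tolerated, a lower number that less compound is tolerated), compound 1 gives 81300 nM, the only true number among the three results. For compound 2 the result is a limit, < 100000 nM, and not a number. For compound 3 the result is likewise a limit, < 50200 nM. Within the data shown here, compound 1 therefore stands alone as the single anchor of the set; the one measured step, an at least 1.6-fold lower number from compound 1 to compound 3 (0.20 log units; that floor lies within the scatter), sets only a floor, and that floor lies within the scatter, so it shows no change that can be trusted.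

Compound 4 `COc1ccc(CNc2nc3cc(N)cc(N)c3nc2-c2ccccc2)cc1` has not yet been measured. It differs from compound 1 as hydrogen in place of methoxy on an aromatic carbon. Among the measured compounds shown here, no measured step removes a methoxy group; the nearest comparison is the step from compound 1 to compound 3, which adds one and yields no more than a floor inside the scatter. On that basis the expectation for this assay is a step of no size beyond the scatter, in either direction, and the estimated change is a 1.0-fold lower number from compound 1 to compound 4 (0.01 log units; within the scatter). For compound 4 the estimate is 80000 nM, within a range from 35000 nM to 180000 nM.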

Compound 4, concentration lethal to 50% of the cells: < 100000 nM
Compound 4: only a limit was reported (the forecaster's own chance of this, stated with the estimate: 25%); the middle value is on the limit's open side.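

In this assay compound 4 gives < 100000 nM, which is a limit and not a number, so the step from compound 1 to compound 4 cannot be read. The compounds shown leave open whether going from 3,4-dimethoxyphenyl to 4-methoxyphenyl changes the result at all, and limits recur among them: the limit of < 100000 nM in this assay, at which 2 of the 4 values shown sit.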